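Adding an oxygen to the sulfur of compound 3

This account rests on a few compounds, and the source may have more. Where it says the series, first, only, none or still open, it means among the compounds named here.

In a functional assay on the whole organism with Canis familiaris (Canis lupus familiaris) as the target (a lower number here means that less compound is needed, a higher number that more compound is needed for the effect), compound 3 `COc1cc(SC)ccc1-c1cn2ccncc2n1` gives 0.5 mg/kg. That is close to compound 2 `COc1ccc(-c2cn3ccncc3n2)c(OC)c1`, which gives 0.7 mg/kg, while compound 1 `COc1cc(S(C)(=O)=O)ccc1-c1nc2ccncc2[nH]1` shows a clearly lower number at 0.02 mg/kg.

Compound 4 `COc1cc([S+](C)[O-])ccc1-c1cn2ccncc2n1` keeps the core and the methoxy group of compound 3 and alters one substituent: a group of 3 heavy atoms (1 carbon, 1 oxygen, 1 sulfur; no ring) in place of a group of 2 heavy atoms (1 carbon, 1 sulfur; no ring), on an aromatic carbon. Among the compounds with values here, only one measured step bears on this spot, a 1.4-fold lower number from compound 2 to compound 3 (0.15 log units; within the scatter), where methylsulfanyl replaces methoxy on an aromatic carbon. Within the data shown here, that step is small, but it does not test the new group, so no measured step covers this exact change.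

Compound 1 offers a looser hint. It also carries a sulfur group with oxygen, but its core differs as well, so the gap to compound 3 cannot be read as the effect of one change. The value of compound 1 at 0.02 mg/kg shows only that a very low dose is possible among these compounds, and this tilts the expectation gently downward in this assay.

The expected change is a 2.5-fold lower number from compound 3 to compound 4 (0.40 log units; beyond the scatter), a modest shift held with wide uncertainty. The estimate for compound 4 is 0.2 mg/kg, with an expected range from 0.05 mg/kg to 0.7 mg/kg.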

Compound 4, dose for half-maximal effect: 0.1 mg/kg
The estimate for compound 4 lay 2.0-fold (0.30 log units) above the measured number; low and high end bracket the measured number.
By their numbers in this assay, from the lowest: compound 1; then compound 4; then compounds 3 and 2 (each within the scatter of the next).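

Adding an oxygen to the sulfur of the methylsulfanyl group is the first change at this position to move the number in this assay beyond the scatter (a 5.0-fold lower number from compound 3 to compound 4 (0.70 log units; beyond the scatter)). The earlier replacement of methoxy by methylsulfanyl at the same position stayed within the scatter (a 1.4-fold lower number from compound 2 to compound 3 (0.15 log units; within the scatter)), so the sulfur alone brought no readable change, whereas the sulfur with its oxygen did, and the difference also holds against the methoxy compound (a 7.0-fold lower number from compound 2 to compound 4 (0.85 log units; beyond the scatter)). Nothing measured here explains why this one added oxygen lowers the dose needed.

As far as these compounds go, it remains open whether a second oxygen on the same sulfur would lower the number further on this core: compound 1, at 0.02 mg/kg, carries such a group but has a different core as well, so its value cannot be set against that of compound 4 as the result of one change. Also open, from the compounds shown here alone, is how an amine or a carboxylic acid at this position, or a longer chain on the sulfur in place of the methyl, would compare.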